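A few compounds are considered here, and "the series" means these few. Any claim that something is new, unique, unknown or untested is made for them only; others in the source may bear on it.

Working notes on the series

Of the compounds shown here, two have been measured. Compound 1, `Cc1cc(C)cc(SCc2ccc(/C=C/C(=O)Nc3ccccc3N)cc2)c1`, gives 2.49% in a functional assay on A-375 cells (Homo sapiens) for inhibition, read by CCK-8 assay, with a stated time of 72 h, tested at 8 uM; a lower number here means less inhibition of growth, a higher number more inhibition of growth at the concentration tested. Compound 2, `Nc1ccccc1NC(=O)c1ccc(CSc2cccc(F)c2)cc1`, gives 76.3% in this assay, which is the higher of the two numbers; the gap to compound 1 lies well beyond the scatter. Compound 1 and compound 2 differ in more than one place, so no single structural step can be read from that pair; only the two values themselves stand.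

Compound 3, `Nc1ccccc1NC(=O)c1ccc(CSc2ccc(Cl)cc2)cc1`, has not yet been measured. It differs from compound 2 in one place: 4-chlorophenyl in place of 3-fluorophenyl on a sulfur. Among the measured compounds shown here, no step between measured compounds of this kind exists, so the size of the effect cannot be taken from the data. The change keeps the count of heavy atoms, donors and acceptors and exchanges one halogen-bearing phenyl for another, so a step of no more than the usual scatter, in either direction, is expected, with a modest drop somewhat more likely than a gain given that compound 2 already sits high.

The step from compound 2 to compound 3 is thus expected to be a number 6.3 percentage points lower from compound 2 to compound 3 (within the scatter). For compound 3 in this assay a value of 70% is estimated, with a range from 45% to 90%.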

Compound 3, percent growth inhibition at one concentration: 48.6%
For compound 3 the middle estimate is 21.4 percentage points above the measured one; the measured number falls inside the stated range.
By their numbers in this assay, from the lowest: compound 1; then compound 3; then compound 2.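

Among the compounds shown here, the exchange of 3-fluorophenyl for 4-chlorophenyl on a sulfur is the only single-place step, and in this assay it gives a number 27.7 percentage points lower from compound 2 to compound 3 (beyond the scatter) and so supplies a size for a change at this place. The position, on a sulfur whose other neighbour is a saturated chain carbon, is therefore not indifferent to which halogen-bearing phenyl it carries, although both groups count the same heavy atoms, with no hydrogen-bond donors or acceptors and no net charge. No measurement at hand bears on the reason for this step.

This one step does not tell the change of halogen apart from the change of its place on the phenyl, since both change together between compound 2 and compound 3. Also open, going by these compounds, is whether a plain phenyl, a methoxyphenyl or an aminophenyl on the same sulfur would stand nearer to compound 2 or to compound 3, and whether a longer chain in place of the saturated chain carbon would keep the growth inhibition seen for compound 2.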